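The source may report more compounds than this note shows. Statements on the series, on what has been measured and on what is new or still open speak of the compounds shown alone.

Measured compounds so far:
compound 1 `O=S(=O)(Nc1ccc2oc(-c3ccccc3)nc2c1)c1cccc(F)c1`, in an assay on isolated protein for inhibition of malate dehydrogenase, mitochondrial (Sus scrofa), with stated times of 45 min and 30 min; a higher number here means a weaker inhibitor, a lower number a stronger inhibitor: > 63000 nM, a limit
compound 2 `CS(=O)(=O)Nc1ccc(-c2nc3ccccc3o2)cc1`, in this assay: > 63000 nM, a limit
compound 3 `O=S(=O)(Nc1ccc2oc(-c3ccccc3)nc2c1)c1ccc(Cl)c(C(F)(F)F)c1`, in this assay: > 63000 nM, a limit

Compound 2 stands at the limit of this assay; its value is a limit rather than a number, and the two further values shown are limits as well. Going by the values given here, no two measured compounds differ in one place, so no measured step can be stated. Compound 4 `COc1ccc(Cl)cc1S(=O)(=O)Nc1ccc(-c2nc3ccccc3o2)cc1` differs from compound 2 by 5-chloro-2-methoxyphenyl in place of methyl on a sulfonyl sulfur. Because the limit of > 63000 nM in this assay, at which 3 of the 3 values shown sit, covers every value shown, compound 4 is expected to remain close to that limit. The step of an at least 1.5-fold lower number from compound 2 to compound 4 (0.19 log units; that floor lies within the scatter) is expected to lie within the scatter, or at most modestly toward a stronger value. Compound 4 is estimated at 40000 nM, within a range of 8000 nM to 200000 nM.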

Compound 4, half-maximal inhibitory concentration: > 63000 nM
Compound 4 ended at the assay's limit; the forecaster's own chance of this, stated with the estimate: 55%; middle value at least 1.5-fold (0.19 log units) away from the limit.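

Compound 2 and compound 4 both carry limits, not numbers, and the step between them cannot be read. The compounds shown leave open whether any group on the sulfonyl sulfur gives a measurable inhibition value rather than a limit.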